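The source may report more compounds than this note shows. Statements on the series, on what has been measured and on what is new or still open speak of the compounds shown alone.

Series notes. Of the compounds shown here, two of this set carry a measured value so far. Compound 1 `COC(=O)/C=C/c1cccc(N(Cc2ccc(-c3cccc(OC)c3)cc2)C(=O)NC(C)C)c1` and compound 2 `COC(=O)/C=C/c1cccc(N(Cc2ccc(-c3cccc(Cl)c3)cc2)C(=O)C(C)C)c1` share the same core but differ in two places at once: the group on the outer aromatic ring and the group on the nitrogen. In an assay on isolated protein with Bile acid receptor (Homo sapiens) as the target (a higher number here means that more compound is needed for the effect, a lower number that less compound is needed), compound 1 gives 1370 nM, while compound 2 gives 77 nM. Compound 2 therefore stands at the lowest number of the two shown, and the gap to compound 1 lies well beyond the usual scatter. For the measured compounds named here, no single-change step between measured compounds exists here, so these two values are noted only as they stand.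

Compound 3 `COC(=O)/C=C/c1cccc(N(Cc2ccc(-c3cccc(OC)c3)cc2)C(=O)C(C)C)c1` keeps the nitrogen group of compound 2 and changes only the outer ring: methoxy in place of chloro on an aromatic carbon. The change is that of methoxy in place of chloro on an aromatic carbon. Compound 1 also carries the methoxy, but it carries the other nitrogen group as well, so the methoxy's share of the gap between compound 1 and compound 2 is not separable from the data.

For compound 3 the step of a 3.2-fold higher number from compound 2 to compound 3 (0.51 log units; beyond the scatter) is expected to go toward a higher number, of moderate size. Compound 3 is estimated at 250 nM in this assay, within a range from 80 nM to 800 nM.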

Compound 3, half-maximal effective concentration: 72 nM
Compound 3: middle estimate off by 3.5-fold (0.54 log units), on the high side; measured number outside the range, below it.
By their numbers in this assay, from the lowest: compounds 3 and 2 (each within the scatter of the next); then compound 1.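

In this assay, methoxy in place of chloro on an aromatic carbon, meta to a large group, gives a 1.1-fold lower number from compound 2 to compound 3 (0.03 log units; within the scatter), so the two groups cannot be told apart at this position, with isopropyl on the carbonyl carbon. With the methoxy held constant, isopropyl in place of isopropylamino on the carbonyl carbon gives a 19-fold lower number from compound 1 to compound 3 (1.28 log units; beyond the scatter); of the one-place steps now readable, the large one therefore belongs to the group on the carbonyl carbon and not to the group on the outer ring. Nothing on hand accounts for either step.

Still open, as far as these compounds go, is whether the outer ring position tolerates groups of another kind, such as an amine or a carboxylic acid, and whether chloro and methoxy stay within the scatter of each other when the carbonyl carbon carries isopropylamino. Also open, from the compounds shown here alone, is how a longer chain or a cyclopropyl group on the carbonyl carbon would compare with isopropyl and isopropylamino.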